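Replacing a Hydroxymethylphenyl Group with Pyridinyl on the Core

The compounds below may be only part of what the source reports. "The series", "measured", "known", "first", "only" and "open" are said of these compounds alone.

Compound 1, `C[C@@H](O[C@H]1CN2C(=O)C=C(c3ccc(C#N)cc3)CC2[C@@H]1c1ccc(F)cc1)c1cc(C(F)(F)F)cc(C(F)(F)F)c1`, gives 1.8 nM in an assay on CHO cells for displacement of a labelled ligand from Substance-P receptor (Homo sapiens); on this read-out lower numbers stand for stronger inhibition and higher numbers for weaker inhibition.
Compound 2, `C[C@@H](O[C@H]1CN2C(=O)C=C(c3ccc(F)cc3)CC2[C@@H]1c1ccc(F)cc1)c1cc(C(F)(F)F)cc(C(F)(F)F)c1`, gives 2 nM.
Compound 3, `C[C@@H](O[C@H]1CN2C(=O)C=C(c3ccc(CO)cc3)CC2[C@@H]1c1ccc(F)cc1)c1cc(C(F)(F)F)cc(C(F)(F)F)c1`, gives 0.39 nM.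

Compound 3 gives the lowest number of the three, and its steps to both neighbours lie beyond the scatter: a 4.6-fold lower number from compound 1 to compound 3 (0.66 log units; beyond the scatter) and a 5.1-fold lower number from compound 2 to compound 3 (0.71 log units; beyond the scatter). Compound 4, `C[C@@H](O[C@H]1CN2C(=O)C=C(c3ccncc3)CC2[C@@H]1c1ccc(F)cc1)c1cc(C(F)(F)F)cc(C(F)(F)F)c1`, has not been measured yet. It differs from compound 3 in one place: pyridin-4-yl in place of 4-(hydroxymethyl)phenyl on a double-bonded ring carbon. Among the compounds with values here, no measured pair shows exactly this exchange, but the two steps into compound 3 show that the hydroxymethyl group sets compound 3 apart from compound 1 and compound 2, whose numbers sit within the scatter of each other (a 1.1-fold higher number from compound 1 to compound 2 (0.05 log units; within the scatter)). Compound 4 loses that hydroxymethyl group, so the expectation is that its number moves back toward those of compound 1 and compound 2, an expected step of a 6.4-fold higher number from compound 3 to compound 4 (0.81 log units; beyond the scatter). Compound 4 is therefore estimated at 2.5 nM, with a range from 0.8 nM to 8 nM.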

Compound 4, half-maximal inhibitory concentration: 0.14 nM
Estimate against measurement, compound 4: 18-fold (1.25 log units) above; the whole stated range lies above it.
By their numbers in this assay, from the lowest: compound 4; then compound 3; then compounds 1 and 2 (each within the scatter of the next).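

In this assay, a hydroxymethyl group is not needed for a low number at this position: the pyridin-4-yl group has none, and 0 hydrogen-bond donors, yet it gives a 2.8-fold lower number from compound 3 to compound 4 (0.44 log units; beyond the scatter). The gain is larger against the two groups that had looked alike, with a 14-fold lower number from compound 2 to compound 4 (1.15 log units; beyond the scatter) and a 13-fold lower number from compound 1 to compound 4 (1.11 log units; beyond the scatter). Among these four compounds, then, the ring carrying the ring nitrogen gives the lowest number, and a substituent on a carbon-only aromatic ring does not have to be present for strong inhibition.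

The data shown offer no measured explanation for these steps. Also open, as far as these compounds go, is how an amine, a carboxylic acid or a longer chain ending in a hydroxyl on the pyridine ring would fare in this assay.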